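The source may report more compounds than this note shows. Statements on the series, on what has been measured and on what is new or still open speak of the compounds shown alone.

Measured in a functional assay on PA-1 cells (Homo sapiens) for cytotoxicity, read by MTT assay, with stated times of 6 h and 48 h; on this read-out lower numbers stand for stronger inhibition and higher numbers for weaker inhibition:
- Compound 1 `Cn1c(/C=C/C(=O)c2ccccc2O)cc(Br)c1Br`: 1250 nM
- Compound 2 `Cn1c(/C=C/C(=O)c2ccccc2)cc(Br)c1Br`: >= 100000 nM, a limit

Compound 2 stands at the limit of >= 100000 nM in this assay, at which 1 of the 2 values shown sits, so it has no exact number. Compound 3 `Cn1c(/C=C/C(=O)c2ccc[nH]2)cc(Br)c1Br` carries 1H-pyrrol-2-yl in place of phenyl on a carbonyl carbon. Among the compounds with values here, the one measured step that bears on this is large: an at least 80-fold higher number from compound 1 to compound 2 (1.90 log units; beyond the scatter), with hydrogen in place of hydroxy on an aromatic carbon. The incoming group again counts a hydrogen-bond donor, so a partial return toward compound 1 at 1250 nM is expected in this assay. The expected change is an at least 10-fold lower number from compound 2 to compound 3 (1.00 log units; beyond the scatter), toward stronger inhibition. Compound 3 is estimated at 10000 nM, within an expected range of 1500 nM to 60000 nM.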

Compound 3, half-maximal inhibitory concentration: 730 nM
Beside the measured number, compound 3's estimate is 14-fold (1.14 log units) above it, and the stated range ends above it.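

Compound 2 has only a limit in this assay: the limit of >= 100000 nM in this assay, at which 1 of the 3 values shown sits. At the carbonyl carbon, 1H-pyrrol-2-yl in place of phenyl gives an at least 130-fold lower number from compound 2 to compound 3 (2.13 log units; beyond the scatter), so activity returns here with no hydroxy on a phenyl ring. In this assay, compound 1 at 1250 nM and compound 3 at 730 nM lie within the usual scatter of each other, so two different groups carrying a hydrogen-bond donor read alike here. This change swaps the ring and adds the donor together, so the compounds shown cannot separate the two; a furan-2-yl or 1-methyl-1H-pyrrol-2-yl group at this place would bear on that question.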